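The source may report more compounds than this note shows. Statements on the series, on what has been measured and on what is new or still open speak of the compounds shown alone.

Compound 1, with structure `O=C1/C(=C/N2N=C(c3ccccc3)CC2c2ccccc2O)SC(=S)N1c1cccc(C(F)(F)F)c1`, gives > 10000 nM in a functional assay on SK-OV-3 cells (Homo sapiens) for antiproliferative activity, read by MTT assay, with a stated time of 72 h (a higher number here means a weaker inhibitor, a lower number a stronger inhibitor), a limit of the assay rather than a number.
Compound 2, with structure `O=C1NC(=S)S/C1=C\N1N=C(c2ccc(Cl)cc2)CC1c1ccc(Cl)cc1`, gives 9140 nM.
Compound 3, with structure `CC(=O)Oc1ccc(N2C(=O)/C(=C/N3N=C(c4ccc(Cl)cc4)CC3c3ccc(Cl)cc3)SC2=S)cc1`, gives > 10000 nM, again a limit of the assay.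

Compound 3 thus stands at the upper edge of what this assay reports, and the limit of > 10000 nM in this assay, at which 2 of the 3 values shown sit, is where it sits alongside compound 1. Within the data shown here, the single measured step that reaches it, an at least 1.0-fold higher number from compound 2 to compound 3 (0.03 log units; that floor lies within the scatter), is a floor that lies within the scatter, so it tells little about whether the 4-acetoxyphenyl group on the amide-type nitrogen moves the number at all.

Compound 4, with structure `CC(=O)Oc1ccc(N2C(=O)/C(=C/N3N=C(c4ccc5ccccc5c4)CC3c3ccc(Cl)cc3)SC2=S)cc1`, differs from compound 3 in one place: naphthalen-2-yl in place of 4-chlorophenyl on a carbon with a double bond to nitrogen. Among the measured compounds shown here, no measured step touches that carbon, and the other substituent on it, the 4-chlorophenyl group, is kept. With both compound 1 and compound 3 at the limit and compound 2 close to it, there is nothing here that points to a large gain in potency from the change.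

Compound 4 is therefore expected to give about 15000 nM in this assay, within a range from 5000 nM to 50000 nM. The step that the limit leaves unreadable from compound 3 to compound 4 that this estimate means is expected to stay within the scatter, most likely as another limit.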

Compound 4, half-maximal inhibitory concentration: > 10000 nM
Compound 4 was reported as a limit (the forecaster's own chance of this, stated with the estimate: 70%); the middle value lies beyond the limit too.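

Among these compounds, compound 4, like compound 3, is reported only as a limit, so the change from 4-chlorophenyl to naphthalen-2-yl gives no step that can be read between compound 3 and compound 4: the limit of > 10000 nM in this assay, at which 3 of the 4 values shown sit. The compounds shown leave open whether naphthalen-2-yl changes the number in this assay at all, since neither compound has a value beyond its limit.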